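The source may report more compounds than this note shows. Statements on the series, on what has been measured and on what is new or still open speak of the compounds shown alone.

Working notes on the series.

Of the compounds shown here, three have been measured in an ADME assay on MT4 cells (Homo sapiens) for cytotoxicity, read by MTT assay, with a stated time of 5 days; on this read-out higher numbers stand for lower toxicity in this test and lower numbers for higher toxicity in this test. Compound 1 `Cc1cc(C#N)cc(C)c1Oc1cc(Nc2ccc(C#N)cc2)[nH]c(=O)c1Cl` is the only one here carrying a cyano on the outer ring; compound 3 `Cc1cc(C)c(Oc2cc(Nc3ccc(C#N)cc3)[nH]c(=O)c2Cl)c(C)c1` shares its core and replaces that cyano with a methyl. Compound 2 `Cc1cc(C)c(Oc2cc(Nc3ccc(C#N)cc3)[nH]c(=O)c2)c(C)c1` carries the cyano on the aniline side but lacks the chloro of compound 3; the difference between the core of compound 2 and the core of compound 1 is not broken down here.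

In this assay compound 1 gives only a limit, > 319000 nM. Compound 3 likewise gives only a limit, > 329000 nM. Compound 2 gives a number, 32000 nM. The change from compound 1 to compound 3, (methyl in place of cyano on an aromatic carbon), produced a step that the two limits leave unreadable from compound 1 to compound 3, since both ends sit at the limit of > 319000 nM in this assay, at which 1 of the 3 values shown sits, and (the limit of > 329000 nM in this assay, at which 1 of the 3 values shown sits). The chloro step gives an at least 10-fold higher number from compound 2 to compound 3 (1.01 log units; beyond the scatter).

Compound 4 `Cc1ccc(Nc2cc(Oc3c(C)cc(C)cc3C)cc(=O)[nH]2)cc1` is not yet measured. It differs from compound 2 by methyl in place of cyano on an aromatic carbon; this is the same kind of change as from compound 1 to compound 3, though the surroundings differ: in compound 3 the methyl also stands meta to two methyl groups, while in compound 4 it stands only para to a large group. As the earlier step could not be read, the estimate for compound 4 in this assay rests on compound 2 alone and is expected to be a 1.3-fold lower number from compound 2 to compound 4 (0.11 log units; within the scatter), giving an expected value of 25000 nM for compound 4, with a range from 8000 nM to 80000 nM.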

Compound 4, half-maximal cytotoxic concentration: 37000 nM
For compound 4 the middle estimate is 1.5-fold (0.17 log units) below the measured one, within the range that was stated.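

In this assay, putting methyl in place of cyano on the 4-cyanophenyl group gives a 1.2-fold higher number from compound 2 to compound 4 (0.06 log units; within the scatter), so on the core of compound 2 the two values cannot be told apart. The same kind of change on the chlorinated core, at the cyano of the other aromatic ring, offers no second reading: the step from compound 1 to compound 3 cannot be read, as both of its ends are limits of the assay and not numbers. This is therefore a single readable case on a single core, which shows that the change is tolerated within the scatter for the pair compound 2 and compound 4, but does not show that it would carry over to the core of compound 3 or to the other ring.

On these data alone, it remains open whether the chloro step, an at least 10-fold higher number from compound 2 to compound 3 (1.01 log units; beyond the scatter), would appear in the same way with the 4-methylphenyl group of compound 4 in place of the 4-cyanophenyl group. As far as these compounds go, it is also open how this assay would read with an amine, a carboxylic acid or a longer chain at the place on the ring now held by cyano or methyl.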